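This account rests on a few compounds, and the source may have more. Where it says the series, first, only, none or still open, it means among the compounds named here.

Measured compounds in a functional assay on HT-29 cells (Homo sapiens) for cytotoxicity, read by MTT assay, with a stated time of 72 h; on this read-out lower numbers stand for stronger inhibition of growth and higher numbers for weaker inhibition of growth:
- compound 1 `COc1ccc(OC(=O)Nc2ccc([Se]C#N)cc2)cc1` gives 13600 nM
- compound 2 `O=C(Nc1ccc([Se][Se]c2ccc(NC(=O)OCc3ccccc3)cc2)cc1)OCc1ccccc1` gives 1800 nM
- compound 3 `O=C(Nc1ccc([Se][Se]c2ccc(NC(=O)Oc3ccc(F)cc3)cc2)cc1)Oc1ccc(F)cc1` gives 18500 nM

Among these three numbers, compound 1 has the second highest. Its nearest neighbour is compound 3, whose value sits within the usual scatter of compound 1, so the two cannot be told apart. Compound 2 stands furthest away, with a number beyond the scatter lower than that of compound 1, meaning stronger inhibition of growth.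

Compound 4 `N#C[Se]c1ccc(NC(=O)Oc2ccc(Cl)cc2)cc1` has not yet been measured. It differs from compound 1 in one place: chloro in place of methoxy on an aromatic carbon, para to a large group on the ring. Among the compounds with values here, no measured pair shows what such an exchange does here. The step from compound 1 to compound 4 is expected to be small, a 1.1-fold lower number from compound 1 to compound 4 (0.05 log units; within the scatter), with no direction claimed beyond the scatter. Compound 4 is therefore estimated at 12000 nM, within 5000 nM to 30000 nM.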

Compound 4, concentration for 50% growth inhibition: 11800 nM
Estimate against measurement, compound 4: 1.0-fold (0.01 log units) above; measured number inside the range.
By their numbers in this assay, from the lowest: compound 2; then compounds 4, 1 and 3 (each within the scatter of the next).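

In this assay, within the data shown here, chloro in place of methoxy on this aromatic carbon gives a 1.2-fold lower number from compound 1 to compound 4 (0.06 log units; within the scatter) and so offers the first direct reading at this position. Here, a group of carbon and oxygen and a single chlorine atom cannot be told apart, so this exchange leaves growth inhibition unchanged within the scatter. Nothing available explains why the two groups read alike.

Going by these compounds, whether an amine or a carboxylic acid at this position would also match methoxy and chloro remains open. So does the effect of a longer chain there.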